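A Pyridyl Ring in Place of the Methoxyphenyl Group

The compounds below may be only part of what the source reports. "The series", "measured", "known", "first", "only" and "open" are said of these compounds alone.

Compound 1 `COc1ccc(-c2nnc(CNc3c(C)n(C)n(-c4ccccc4)c3=O)o2)cc1` carries the highest of the three numbers in a physicochemical assay for lipophilicity, measured as octanol-water partition (on this read-out lower numbers stand for lower lipophilicity and higher numbers for higher lipophilicity), at 2.07, though compound 3 `CC(=O)Oc1ccccc1-c1nnc(CNc2c(C)n(C)n(-c3ccccc3)c2=O)o1` stands within the scatter of it at 1.98. Compound 2 `Cc1c(NCc2nnc(-c3ccc(N)cc3)o2)c(=O)n(-c2ccccc2)n1C` lies lowest at 1.13. Compound 4 `Cc1c(NCc2nnc(-c3ccncc3)o2)c(=O)n(-c2ccccc2)n1C` differs from compound 1 by pyridin-4-yl in place of 4-methoxyphenyl on an aromatic carbon. Going by the values given here, no measured step covers this exact exchange. The closest guides are a number 0.94 log units lower from compound 1 to compound 2 (beyond the scatter), a modest fall on swapping the substituent of the same ring, and a number 0.09 log units lower from compound 1 to compound 3 (within the scatter), where exchanging the whole aryl group left the number unchanged. Replacing the ring of carbon only with one bearing a ring nitrogen is expected to lower this assay beyond the scatter, by a number 1.27 log units lower from compound 1 to compound 4 (beyond the scatter). Compound 4 is therefore estimated at 0.8, between 0.3 and 1.3.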

Compound 4, partition coefficient: 0.8
The estimate for compound 4 equals the measured number at the digits printed; the range from low to high includes it.
By their numbers in this assay, from the lowest: compound 4; then compound 2; then compounds 3 and 1 (each within the scatter of the next).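

At this position, an exchange of the whole aryl group can move this assay well beyond the scatter: pyridin-4-yl in place of 4-methoxyphenyl gives a number 1.27 log units lower from compound 1 to compound 4 (beyond the scatter) and, in place of 2-acetoxyphenyl, a number 1.18 log units lower from compound 3 to compound 4 (beyond the scatter) even though 2-acetoxyphenyl and 4-methoxyphenyl had stood within the scatter of each other. Pyridin-4-yl also goes lower than 4-aminophenyl, with a number 0.33 log units lower from compound 2 to compound 4 (beyond the scatter) so a ring nitrogen reaches further here than the amino group on a ring of carbon only. As far as these compounds go, how a carboxylic acid or a morpholine on the same ring would compare remains open. Nothing shown here explains these falls.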